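Methyl on the Five-Membered Ring: Cytotoxicity Outlook for Compound 4

This account rests on a few compounds, and the source may have more. Where it says the series, first, only, none or still open, it means among the compounds named here.

Measured so far:
- compound 1, `CC1(C)OC(=O)C(=CNc2ccc3cn[nH]c3c2)C(=O)O1`: > 250000 nM
- compound 2, `CC1(C)OC(=O)C(=CNc2ccc3[nH]c(=O)[nH]c3c2)C(=O)O1`: > 500000 nM
- compound 3, `CC1(C)OC(=O)C(=CNc2ccc3ncsc3c2)C(=O)O1`: > 500000 nM

Of the compounds shown here, three sharing one core have been tested in an ADME assay on THP-1 cells (Homo sapiens) for cytotoxicity, read by flow cytometry and propidium iodide staining, with a stated time of 72 h; a higher number here means a weaker inhibitor, a lower number a stronger inhibitor. For compound 1 the result is a limit only, > 250000 nM. For compound 2 the result is likewise a limit, > 500000 nM. For compound 3 the result is again a limit, > 500000 nM. Compound 3 therefore stands at the limit of > 500000 nM in this assay, at which 2 of the 3 values shown sit, while the remaining value sits at the limit of > 250000 nM in this assay, at which 1 of the 3 values shown sits. Among the compounds with values here, no true number exists among the three, so no step between measured compounds can be sized.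

The next compound is compound 4, `Cc1nc2ccc(NC=C3C(=O)OC(C)(C)OC3=O)cc2s1`. Relative to compound 3 the change is small: methyl in place of hydrogen on an aromatic carbon. With every measured value a limit, nothing in these data points to a step in either direction; the expected step from compound 3 to compound 4 in this assay is none beyond the scatter, and the estimated step is a number no higher from compound 3 to compound 4 (the limit leaves the size open). The expected result for compound 4 in this assay is 500000 nM, in the range 150000 nM to 1500000 nM.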

Compound 4, half-maximal inhibitory concentration: > 250000 nM
Compound 4: a limit, no number; the forecaster's own chance of this, stated with the estimate: 85%; the middle value does not contradict the limit.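

Compound 3 and compound 4 both return only limits in this assay, so the step for methyl in place of hydrogen on an aromatic carbon cannot be read. The compounds shown leave open what true value any of them has, and therefore whether this methyl changes it.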